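Compound 4 and the aryl group on the nitrogen

This account rests on a few compounds, and the source may have more. Where it says the series, first, only, none or still open, it means among the compounds named here.

Three compounds share one core and differ only in the aryl group on a nitrogen on an aromatic ring. Compound 1 `CCc1ccc(Nc2cc(NC(=O)Nc3cc(OC)cc(OC)c3)ncn2)cc1` gives 32.7% in a functional assay on NCI-H1581 cells (Homo sapiens) for inhibition, read by MTT assay, with a stated time of 48 h, tested at 10 uM; a lower number here means less inhibition, a higher number more inhibition at the concentration tested (going by the name of the read-out). Compound 2 `COc1cc(NC(=O)Nc2cc(Nc3cc(F)ccc3OC)ncn2)cc(OC)c1` gives 42.1%. Compound 3 `COc1cc(NC(=O)Nc2cc(Nc3ccc(Br)cc3OC)ncn2)cc(OC)c1` gives 20.1%, the lowest of the three numbers. The step of a number 12.6 percentage points lower from compound 1 to compound 3 (beyond the scatter) and the step of a number 22 percentage points lower from compound 2 to compound 3 (beyond the scatter) both lie beyond the scatter, whereas the step of a number 9.4 percentage points higher from compound 1 to compound 2 (within the scatter) does not. Compound 4 `COc1cc(NC(=O)Nc2cc(Nc3ccc(OC)c(C)c3)ncn2)cc(OC)c1` carries the change (4-methoxy-3-methylphenyl in place of 4-bromo-2-methoxyphenyl on a nitrogen on an aromatic ring). Going by the values given here, no measured step covers this exact exchange; what the measured steps show is that replacing the aryl group on this nitrogen shifts the read-out by modest amounts, and that compound 3 sits at the low end of the three. On that basis compound 4 is expected to move back up toward the numbers of compound 1 and compound 2 rather than lower still. Compound 4 is therefore expected to show a step of a number 9.9 percentage points higher from compound 3 to compound 4 (within the scatter) in this assay. Compound 4 is estimated at 30%, within a range from 15% to 45%.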

Compound 4, a percentage reported as inhibition, at one concentration (the size of the read-out at that concentration, not a potency): 19.7%
Compound 4: middle estimate off by 10.3 percentage points, on the high side, within the range that was stated.
By their numbers in this assay, from the lowest: compounds 4 and 3 (each within the scatter of the next); then compounds 1 and 2 (each within the scatter of the next).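

In this assay, 4-methoxy-3-methylphenyl in place of 4-bromo-2-methoxyphenyl on the nitrogen gives a number 0.4 percentage points lower from compound 3 to compound 4 (within the scatter), so these two differently substituted aryl groups cannot be told apart at this position. Compound 4 carries no bromine, yet the other two steps, a number 22.4 percentage points lower from compound 2 to compound 4 (beyond the scatter) and a number 13 percentage points lower from compound 1 to compound 4 (beyond the scatter), place it with compound 3 at the low end of the four, so the low number of compound 3 is not tied to bromine among these compounds. The data at hand offer no explanation for this separation among the aryl groups.

The compounds shown leave open how an aryl group bearing an amine or a carboxylic acid would read on this nitrogen. They also leave open whether a plain phenyl would fall with compound 1 and compound 2 or with compound 3 and compound 4.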